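This account rests on a few compounds, and the source may have more. Where it says the series, first, only, none or still open, it means among the compounds named here.

Compound 1 `O=C(Sc1cccnc1C(=O)O)c1ccccc1`: 21.1 h
Compound 2 `O=C(Sc1cccnc1C(=O)O)c1ccccc1Cl`: 27.2 h

In a physicochemical assay for pharmacokinetics, at pH 6 (a higher number here means that the compound lasts longer, a lower number that the compound disappears faster), compound 1 gives 21.1 h and compound 2 gives 27.2 h, so the two stand level within the scatter and compound 1 has no measured neighbour that clearly separates from it. Compound 3 `O=C(Sc1cccnc1C(=O)O)c1ccc(Cl)cc1` departs from compound 1 by one change: chloro in place of hydrogen on an aromatic carbon. The chloro takes the place of hydrogen on an aromatic carbon, para to a large group. For the measured compounds named here, only one measured step bears on this, the same kind of exchange made elsewhere on the molecule: a 1.3-fold higher number from compound 1 to compound 2 (0.11 log units; within the scatter). That is one step at a different place, so it gives only a weak guide, and no shift beyond the scatter is expected in this assay. The expected step is a 1.1-fold lower number from compound 1 to compound 3 (0.02 log units; within the scatter). For compound 3 the estimated half-life is 20 h, with an expected range from 12 h to 33 h.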

Compound 3, half-life: 7.9 h
For compound 3 the middle estimate is 2.5-fold (0.40 log units) above the measured one; measured number outside the range, below it.
By their numbers in this assay, from the lowest: compound 3; then compounds 1 and 2 (each within the scatter of the next).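

In this assay, chloro in place of hydrogen on an aromatic carbon, para to a large group, gives a 2.7-fold lower number from compound 1 to compound 3 (0.43 log units; beyond the scatter), a modest step and the first shown here to clear the scatter. The same exchange at another place on the molecule gave a 1.3-fold higher number from compound 1 to compound 2 (0.11 log units; within the scatter), so across these two steps the effect of chloro differs with where it stands, and this position is the one that responds. Nothing measured here accounts for that difference.

As far as these compounds go, what remains open is whether the shorter half-life belongs to chloro itself or would also follow from another group at this position, such as fluoro, methyl, methoxy or an amine. A single step also leaves unsettled how far the same exchange would carry over to a different core.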